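The compounds below may be only part of what the source reports. "The series", "measured", "known", "first", "only" and "open" are said of these compounds alone.

Working notes on the series. All three compounds share one saturated bicyclic core carrying an amine whose methylene bears an aromatic group. Among the compounds with values here, compound 1 `CCCc1ccsc1CN[C@@H]1C[C@H]2C[C@@H]([C@H]1C)C2(C)C` is the first measured member; in an ADME assay on MDCK cells (Canis lupus familiaris) for cytotoxicity, read by microscopy, with a stated time of 48 h (on this read-out higher numbers stand for lower toxicity in this test and lower numbers for higher toxicity in this test), compound 1 gives 50000 nM. Compound 2 `C[C@H]1[C@H](NCc2cncnc2)C[C@H]2C[C@@H]1C2(C)C` carries pyrimidin-5-yl on that position. In this assay compound 2 gives > 100000 nM, which is a limit of the assay and not a number. Compound 2 therefore sits at the upper edge of the measured range, as recorded in the limit of > 100000 nM in this assay, at which 1 of the 2 values shown sits, while compound 1 returns a value inside the range.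

Compound 3 `C[C@H]1[C@H](NCc2sccc2Br)C[C@H]2C[C@@H]1C2(C)C` is not yet measured. It differs from compound 2 by 3-bromothiophen-2-yl in place of pyrimidin-5-yl on a saturated chain carbon bound to an amine nitrogen. Within the data shown here, no step between measured compounds exists to calibrate the change, so its size in this assay is uncertain. Compound 1, which also carries a thiophene-type group, gives 50000 nM, and compound 3 is expected to land nearer that value. The expected step is an at least 1.6-fold lower number from compound 2 to compound 3 (0.22 log units; that floor lies within the scatter), a modest move toward lower numbers, though a step within the scatter is also possible. For compound 3 the estimate is 60000 nM, with a range from 20000 nM to 100000 nM.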

Compound 3, minimum cytotoxic concentration: 50000 nM
For compound 3 the middle estimate is 1.2-fold (0.08 log units) above the measured one; low and high end bracket the measured number.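

Within the data shown here, the replacement of pyrimidin-5-yl by 3-bromothiophen-2-yl on a saturated chain carbon bound to an amine nitrogen now has a first readable step in this assay as an at least 2.0-fold lower number from compound 2 to compound 3 (0.30 log units; that floor lies within the scatter) and, being a floor, this step gives no full size for the change. Compound 2 stays a limit of the assay and not a number, so the true distance to it cannot be read: the limit of > 100000 nM in this assay, at which 1 of the 3 values shown sits. With bromo in place of propyl on an aromatic carbon, the series gains its first step between two thiophene-bearing compounds, no change at the digits printed from compound 1 to compound 3 (within the scatter) and, within this pair, this assay does not separate the two substituents.

Two compounds on the thiophene side give too narrow a base to say whether other groups at that aromatic carbon, such as an amine, a carboxylic acid or a longer chain, would also leave the value in place. Going by these compounds, it also remains open whether a six-membered aromatic ring without nitrogen, such as phenyl, would read like pyrimidin-5-yl or like the thiophene-bearing compounds in this assay here.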